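Swapping the aryl group on the core nitrogen: compound 3 to compound 4

The source may report more compounds than this note shows. Statements on the series, on what has been measured and on what is new or still open speak of the compounds shown alone.

Measured compounds:
Compound 1, `O=C(Nc1ccc(Oc2ccnc3[nH]ccc23)cc1)c1cc2cccnc2n(-c2ccccc2)c1=O`: 1580 nM
Compound 2, `O=C(Nc1ccc(Oc2ccnc3[nH]ccc23)cc1)c1cc2cccnc2n(-c2ccc(Br)cc2)c1=O`: no single number reported
Compound 3, `O=C(Nc1ccc(Oc2ccnc3[nH]ccc23)cc1)c1cc2cccnc2n(-c2ccc(F)c(Cl)c2)c1=O`: no single number reported

The three compounds share one core and differ only in the aryl group carried on an aromatic nitrogen. In a functional assay on U-87MG ATCC cells for antiproliferative activity against U-87 MG (Homo sapiens), read by MTT assay, with a stated time of 72 h (on this read-out higher numbers stand for weaker inhibition and lower numbers for stronger inhibition), compound 1 gives 1580 nM. For compound 2 the entry in this assay reads "not determined" (no result reported), and for compound 3 it reads "not determined" (no result reported); so compound 3 stands without a number of its own, and one further compound is in the same position, leaving compound 1 as the only point of reference.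

Compound 4, `O=C(Nc1ccc(Oc2ccnc3[nH]ccc23)cc1)c1cc2cccnc2n(-c2ccc(C(F)(F)F)cc2Cl)c1=O`, is not yet measured. It differs from compound 3 in one place: 2-chloro-4-(trifluoromethyl)phenyl in place of 3-chloro-4-fluorophenyl on an aromatic nitrogen — 2-chloro-4-(trifluoromethyl)phenyl in place of 3-chloro-4-fluorophenyl on an aromatic nitrogen. Within the data shown here, with no measured pair to set a size or direction, no step beyond the usual scatter of this assay can be expected with any confidence. The estimate for compound 4 in this assay rests on compound 1 alone and is expected to lie near 1500 nM, within a range from 400 nM to 6000 nM.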

Compound 4, half-maximal inhibitory concentration: 6030 nM
For compound 4 the middle estimate is 4.0-fold (0.60 log units) below the measured one; measured number outside the range, above it.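

In this assay, the aryl group on the aromatic nitrogen now shows a first measured effect: replacing phenyl with 2-chloro-4-(trifluoromethyl)phenyl gives a 3.8-fold higher number from compound 1 to compound 4 (0.58 log units; beyond the scatter) and so weaker inhibition. The activity therefore responds to what this position carries, and this substituted ring does worse here than plain phenyl. No evidence at hand explains the loss.

Steps involving compound 2 or compound 3 cannot be read, as neither has a number, so this single pair gives no trend across the aryl groups. On these data alone, it remains open whether the chlorine, the trifluoromethyl or the two together account for the loss, and whether a different group on the phenyl ring, such as a methoxy or an amine, would match or improve on compound 1.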